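The source may report more compounds than this note shows. Statements on the series, on what has been measured and on what is new or still open speak of the compounds shown alone.

Measured compounds:
Compound 1, `N#C[C@@]1(NC(=O)[C@@H](CC(=O)N2CCOCC2)CC2CCC(c3ccccc3)CC2)CCN(C2CCCCC2)C1`: 3140 nM
Compound 2, `N#C[C@@]1(NC(=O)[C@@H](CC(=O)N2CCOCC2)CC2CCCCC2)CCN(C2CCCC2)C1`: 75 nM
Compound 3, `N#C[C@@]1(NC(=O)[C@@H](CC(=O)N2CCOCC2)CC2Cc3ccccc3C2)CCN(C2CCCCC2)C1`: 42 nM

In an assay on isolated protein for inhibition of cathepsin S (Homo sapiens) (on this read-out higher numbers stand for weaker inhibition and lower numbers for stronger inhibition), compound 2 stands second highest of the three numbers. Its nearest neighbour is compound 3, and the two lie within the scatter of each other, whereas compound 1 lies far higher, beyond the scatter. Compound 4, `CC(C)N1CC[C@@](C#N)(NC(=O)[C@@H](CC(=O)N2CCOCC2)CC2CCCCC2)C1`, differs from compound 2 by isopropyl in place of cyclopentyl on an amine nitrogen in a ring. Going by the values given here, no measured step touches this amine nitrogen: the only single-point step, a 75-fold lower number from compound 1 to compound 3 (1.87 log units; beyond the scatter), concerns the saturated chain carbon, and compound 1 differs from compound 2 in two places at once. With no direct guide, the expected step is a 2.0-fold higher number from compound 2 to compound 4 (0.30 log units; within the scatter), a small rise in the number that may stay within the scatter. Compound 4 is therefore estimated at 150 nM, with a range from 50 nM to 500 nM.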

Compound 4, half-maximal inhibitory concentration: 66 nM
The estimate for compound 4 lay 2.3-fold (0.36 log units) above the measured number; measured number inside the range.
By their numbers in this assay, from the lowest: compounds 3, 4 and 2 (each within the scatter of the next); then compound 1.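

In this assay the amine nitrogen in a ring takes isopropyl in place of cyclopentyl with a 1.1-fold lower number from compound 2 to compound 4 (0.06 log units; within the scatter) and so stays within the scatter. Going by these compounds alone, this is the first single-point reading at this position, and it shows that the five-membered carbon ring can give way to an open group of 3 heavy atoms with no change beyond the scatter. No measurement offered here accounts for this result.

Going by these compounds, what a methyl group, a benzyl group or an acyl group on this nitrogen would do remains open. So does whether this tolerance would hold with another group on the saturated chain carbon.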